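The source may report more compounds than this note shows. Statements on the series, on what has been measured and on what is new or still open speak of the compounds shown alone.

Working notes on the series. For the measured compounds named here, the only number so far comes from compound 1 (`O=C(CCl)Nc1ccc(Cl)cc1NS(=O)(=O)c1cc(F)cc(F)c1`): in an ADME assay on MT4 cells (Homo sapiens) for cytotoxicity, with a stated time of 5 days (a lower number here means that less compound is tolerated, a higher number that more compound is tolerated), compound 1 gives 179000 nM. Compound 2 (`O=C(CCl)Nc1ccc(Cl)cc1NS(=O)(=O)c1cccc(F)c1`) has no number to place beside it, as the result for compound 2 stands as "not determined" (no result reported). Going by the values given here, its position in this assay is therefore open, and no measured step between two compounds exists to show how far a single substitution moves this read-out.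

Compound 3 (`N#Cc1cccc(S(=O)(=O)Nc2cc(Cl)ccc2NC(=O)CCl)c1`) has not yet been measured. The structural change is cyano in place of fluoro on an aromatic carbon, meta to a large group, or 3-fluorophenyl to 3-cyanophenyl when cut one bond further out.

Among the compounds with values here, with no step to scale from, no direction can be argued, and no shift beyond the usual scatter is expected in this assay. The working reference remains compound 1 at 179000 nM, with a wide margin kept for the thin data. Compound 3 is expected at about 150000 nM, with an estimated range of 50000 nM to 350000 nM.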

Compound 3, half-maximal cytotoxic concentration: > 155000 nM
Compound 3 was reported as a limit (the forecaster's own chance of this, stated with the estimate: 25%); middle value at least 1.0-fold (0.01 log units) from the limit.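

In this assay compound 3 gives > 155000 nM, which is a limit and not a number, and the step from compound 1 to compound 3 cannot be read. The compounds shown leave open how far 3-cyanophenyl in place of 3-fluorophenyl, or any other single change, moves this read-out.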